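From 1-Phenylethyl to 4-Methylphenyl on a Shared Core

The compounds below may be only part of what the source reports. "The series", "measured", "known", "first", "only" and "open" are said of these compounds alone.

In a physicochemical assay for solubility, with a stated time of 24 h, tested at 30 mg/mL (on this read-out lower numbers stand for lower solubility and higher numbers for higher solubility), compound 2 (`C[C@@H](Nc1c(NCCCCCC(=O)NO)c(=O)c1=O)c1ccccc1`) gives 39000000 nM and stands within the scatter of both other measured compounds. Compound 1 (`O=C(CCCCNc1c(Nc2ccccc2)c(=O)c1=O)NO`) gives 32000000 nM in the same measurement and compound 3 (`Cc1ccccc1[C@H](C)Nc1c(NCCCCCC(=O)NO)c(=O)c1=O`) gives 47000000 nM on that scale. Compound 4 (`Cc1ccc(Nc2c(NCCCCCC(=O)NO)c(=O)c2=O)cc1`) differs from compound 2 in one place (4-methylphenyl in place of 1-phenylethyl on a nitrogen on an aromatic ring) with 4-methylphenyl in place of 1-phenylethyl on a nitrogen on an aromatic ring. For the measured compounds named here, no measured step isolates this change. Compound 1 at 32000000 nM and compound 3 at 47000000 nM show only values within the scatter, so no step beyond the scatter is expected in this assay for this change. The expected step of a 1.2-fold lower number from compound 2 to compound 4 (0.09 log units; within the scatter) stays within the scatter. Compound 4 is estimated at 32000000 nM with an expected range of 16000000 nM to 55000000 nM for its measurement.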

Compound 4, solubility: 1800000 nM
Compound 4: the middle estimate sits 18-fold (1.25 log units) above what was measured, and the stated range ends above it.
By their numbers in this assay, from the lowest: compound 4; then compounds 1, 2 and 3 (each within the scatter of the next).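

In this assay, for the compounds shown here, this position now shows a step beyond the scatter, which the earlier compounds did not: 4-methylphenyl in place of 1-phenylethyl on a nitrogen on an aromatic ring gives a 22-fold lower number from compound 2 to compound 4 (1.34 log units; beyond the scatter). The change removes the defined stereocentre and one heavy atom, while one six-membered aromatic ring of carbon only remains. Nothing available explains the step. The compounds shown leave open which part of the change carries it. As far as these compounds go, it also remains open whether benzyl, or a phenyl ring bearing an amine or a carboxylic acid, would read nearer compound 2 or compound 4.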